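This account rests on a few compounds, and the source may have more. Where it says the series, first, only, none or still open, it means among the compounds named here.

Measured in a functional assay on A-375 cells (Homo sapiens) for inhibition, read by CCK-8 assay, with a stated time of 72 h, tested at 8 uM; on this read-out higher numbers stand for more inhibition of growth at the one concentration tested and lower numbers for less inhibition of growth:
Compound 1 (`CCc1ccc(SCc2ccc(C(=O)Nc3ccccc3N)cc2)cc1`): 71.1%
Compound 2 (`Nc1ccccc1NC(=O)c1ccc(CSc2ccc(C(F)(F)F)cn2)cc1`): 5.34%

Of these two numbers, compound 1 holds the higher one (71.1%), and the gap down to compound 2 (5.34%) lies beyond the usual scatter. With so few numbers, little can be said yet about which parts of these molecules matter.

Compound 3 (`Cc1cc(C)cc(SCc2ccc(C(=O)Nc3ccccc3N)cc2)c1`) has not been measured. It keeps the core of compound 1 and carries 3,5-dimethylphenyl in place of 4-ethylphenyl on a sulfur. The atoms are the same and only their arrangement differs, and both groups are six-membered aromatic rings of carbon only. The expectation therefore rests on compound 1 and its value (71.1%). The expected change is a small fall (a number 9.1 percentage points lower from compound 1 to compound 3 (within the scatter)) in this assay and should stay within the scatter. Two measured numbers that lie far apart leave the range wide, mostly on the low side. The estimate for compound 3 is 62% (expected range 30% to 82%).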

Compound 3, percent growth inhibition at one concentration: 74.7%
Beside the measured number, compound 3's estimate is 12.7 percentage points below it, and the stated range covers the measured number.
By their numbers in this assay, from the lowest: compound 2; then compounds 1 and 3 (each within the scatter of the next).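

In this assay, putting 3,5-dimethylphenyl in place of 4-ethylphenyl on a sulfur gives a number 3.6 percentage points higher from compound 1 to compound 3 (within the scatter). The two groups are built from the same atoms and both are six-membered aromatic rings of carbon only, so this step shows that rearranging those carbons, from a single ethyl group to two methyl groups, produces no difference that this read-out can separate from ordinary scatter. This is one step at one concentration, and no measurement shown here explains the result.

On these data alone, the step tests only a rearrangement of carbon atoms, so what happens when the ring on the sulfur carries a methoxy group, an amine or a carboxylic acid remains open, as does the effect of a longer chain such as butyl. Also open, as far as these compounds go, is whether compound 1 and compound 3 would still match at other concentrations, since a single-concentration reading cannot show how their full dose responses compare.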